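The source may hold more compounds than are shown below. What is called first, only, known or untested is meant among the compounds shown, and "the series" means these compounds.

Measured compounds:
compound 1 `O=c1ccc(-c2ccccc2)nn1CCCCNC(=S)NCc1ccccc1`: 5.4%
compound 2 `CC/N=C(/NC#N)NCCCn1nc(-c2ccccc2)ccc1=O`: 62.9%
compound 3 `CC/N=C(/NC#N)NCCCn1nc(C)ccc1=O`: 34.5%

In a functional assay on the whole organism with Rattus norvegicus as the target, at a dose of 100 mg/kg (a higher number here means more inhibition at the dose given (going by the name of the read-out), a lower number less inhibition), compound 3 stands second highest of the three: compound 2 sits higher and compound 1 lower, both gaps beyond the scatter. Compound 4 `CCC/N=C(/NC#N)NCCCn1nc(C)ccc1=O` differs from compound 3 by methyl in place of hydrogen on a saturated chain carbon, two bonds along the chain from a double-bonded nitrogen. Among the compounds with values here, the one measured step, a number 28.4 percentage points lower from compound 2 to compound 3 (beyond the scatter), concerns a change on an aromatic carbon and does not bear on lengthening a saturated chain. Within the data shown here, no measured pair speaks to the change from compound 3 to compound 4, so no step beyond the scatter is expected in this assay, and compound 3 serves as the reference. Compound 4 is therefore expected to give 35% (15% to 55%), an expected step of a number 0.5 percentage points higher from compound 3 to compound 4 (within the scatter).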

Compound 4, a percentage reported as inhibition, in the whole organism at one dose (the size of the read-out at that dose, not a potency): 17.5%
The estimate for compound 4 lay 17.5 percentage points above the measured number; low and high end bracket the measured number.
By their numbers in this assay, from the lowest: compound 1; then compound 4; then compound 3; then compound 2.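

In this assay, the saturated chain on the double-bonded nitrogen proves to matter: ethyl to propyl, methyl in place of hydrogen on a saturated chain carbon, gives a number 17 percentage points lower from compound 3 to compound 4 (beyond the scatter) and so moves the number beyond the scatter. Within the data shown here, the earlier step concerned only a change on an aromatic carbon, so this is the first measured sign that this chain is not indifferent to lengthening. No information at hand accounts for this step.

The compounds shown leave open how a butyl or cyclopropyl group would read in place of the propyl. They also leave open whether the same lengthening would give a similar step with the phenyl of compound 2 in place of the methyl on the aromatic carbon.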